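The compounds below may be only part of what the source reports. "The series", "measured", "known", "first", "only" and "open" are said of these compounds alone.

Compound 1 `CCCCc1oc2ccccc2c1C(=O)c1ccc(OCC(=O)N2CCOCC2)cc1`: 45400 nM
Compound 2 `CCCCc1oc2ccccc2c1C(=O)c1ccc(OCCCC(=O)N2CCCCC2)cc1`: 16600 nM
Compound 3 `CCCCc1oc2ccccc2c1C(=O)c1ccc(OCCCC(=O)N[C@@H](C)c2ccccc2)cc1`: not yet measured

In a functional assay on U-937 cells (Homo sapiens) for antiproliferative activity, read by MTT assay, with a stated time of 24 h (a higher number here means a weaker inhibitor, a lower number a stronger inhibitor), compound 2 gives the lower of the two numbers, 16600 nM. The next structural change leads to compound 3: (1-phenylethyl)amino in place of piperidin-1-yl on a carbonyl carbon. In other words, (piperidin-1-yl)carbonyl becomes (1-phenylethyl)carbamoyl.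

Going by the values given here, only one measured step bears on this, and only loosely: a 2.7-fold lower number from compound 1 to compound 2 (0.44 log units; beyond the scatter). That modest step replaced a (morpholin-4-yl)carbonyl end and altered the chain as well, so it does not isolate the amine part. Among the compounds with values here, no measured compound carries a (1-phenylethyl)carbamoyl group. A step no larger than that one is therefore expected in this assay, leaning weakly towards a lower number and possibly not beyond the scatter. The expected change is a 1.7-fold lower number from compound 2 to compound 3 (0.22 log units; within the scatter). For compound 3 the estimated value is 10000 nM, with an expected range of 3500 nM to 30000 nM.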

Compound 3, half-maximal inhibitory concentration: 22400 nM
Compound 3: the middle estimate sits 2.2-fold (0.35 log units) below what was measured, within the range that was stated.
By their numbers in this assay, from the lowest: compounds 2 and 3 (each within the scatter of the next); then compound 1.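

Measured in this assay the exchange of piperidin-1-yl for (1-phenylethyl)amino on the carbonyl carbon leaves compound 2 and compound 3 within the scatter of each other (a 1.3-fold higher number from compound 2 to compound 3 (0.13 log units; within the scatter)). Unlike the earlier pair, this step changes the amine part alone, and the entering group's amide hydrogen, six-membered aromatic ring of carbon only and defined stereocentre come with no change beyond the scatter. Nothing measured here explains this result.

Still open, going by these compounds, is how the other mirror-image form of the (1-phenylethyl)amino group would read, and whether a benzylamino group on the same carbonyl carbon would separate from piperidin-1-yl. Also open, on these data alone, is what a morpholin-4-yl group would give on the chain of compound 2, which would separate the amine from the chain.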